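The source may report more compounds than this note shows. Statements on the series, on what has been measured and on what is new or still open speak of the compounds shown alone.

Going by the values given here, compound 1, whose structure is `CS(=O)(=O)c1ccc(C(=O)NCC(=O)N(Cc2ccccc2)Cc2ccccc2)cc1[N+](=O)[O-]`, is the only compound in this set that gives an actual number: in an assay on isolated protein for inhibition of thyroid hormone receptor alpha (Homo sapiens), read by fluorescence polarization (a higher number here means a weaker inhibitor, a lower number a stronger inhibitor), compound 1 gives 1700 nM. Compound 2, with the structure `CS(=O)(=O)c1ccc(C(=O)NCCCC(=O)N2Cc3ccccc3C2)cc1[N+](=O)[O-]`, gives in this assay only a limit of the assay, > 60000 nM. Compound 3, with the structure `CC1CCN(C(=O)CCNC(=O)c2ccc(S(C)(=O)=O)c([N+](=O)[O-])c2)CC1`, likewise gives in this assay only a limit, > 60000 nM. So compound 1 stands alone as the one compound for which inhibition was strong enough to be measured, while the other two sit at the limit of > 60000 nM in this assay, at which 2 of the 3 values shown sit.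

Compound 4, whose structure is `CN(Cc1ccccc1)C(=O)CNC(=O)c1ccc(S(C)(=O)=O)c([N+](=O)[O-])c1`, has not been measured. It differs from compound 1 in one place: hydrogen in place of phenyl on a saturated chain carbon bound to an amide-type nitrogen. The change cuts away a phenyl and leaves a smaller group on the amide-type nitrogen.

Among the compounds with values here, no step between two measured compounds is available to anchor how large an effect such a cut has. Since the two compounds that lack the pair of benzyl groups on the amide-type nitrogen give only limits, the expectation is a loss of inhibition beyond the usual scatter, with a step of a 4.1-fold higher number from compound 1 to compound 4 (0.61 log units; beyond the scatter) expected from removing one of those groups. Compound 4 is therefore estimated to give about 7000 nM in this assay, with a likely range from 1700 nM to 40000 nM.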

Compound 4, half-maximal inhibitory concentration: > 60000 nM
Compound 4 ended at the assay's limit; the forecaster's own chance of this, stated with the estimate: 25%; middle value at least 8.5-fold (0.93 log units) away from the limit.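

Going by these compounds alone, compound 4 gives the first comparison in which a single place changes, and it shows that the second benzyl group on the amide-type nitrogen of compound 1 cannot be cut back to methyl without a heavy loss: the change, hydrogen in place of phenyl on a saturated chain carbon bound to an amide-type nitrogen, gives an at least 35-fold higher number from compound 1 to compound 4 (1.54 log units; beyond the scatter). In this assay compound 4 gives > 60000 nM, and this is a limit of the assay, not a number. Within this small set, that one phenyl now separates the only compound with a measured value from the rest, which all share the same limit: the limit of > 60000 nM in this assay, at which 3 of the 4 values shown sit.

The compounds shown leave open whether a phenyl ring is specifically needed at this place, or whether a cyclohexyl ring, a pyridine ring or a longer chain such as phenylethyl in place of the benzyl group would keep the inhibition of compound 1. They also do not tell whether an amine or a carboxylic acid on the phenyl rings of compound 1 would keep or lose it.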